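Adding a hydroxy group at the half-life limit

The compounds below may be only part of what the source reports. "The series", "measured", "known", "first", "only" and "open" are said of these compounds alone.

Measured in an ADME assay; a higher number here means that the compound lasts longer, a lower number that the compound disappears faster (half-life):
- Compound 1 `CCOc1cc(OC)ccc1C[S+]([O-])c1ncccc1C(=O)Nc1ccncc1` gives < 0.02 h (a limit)
- Compound 2 `CCOc1ccc(C[S+]([O-])c2ncccc2C(=O)Nc2ccncc2)c(OCC)c1` gives < 0.02 h (a limit)
- Compound 3 `COc1cc(C)c(C[S+]([O-])c2ncccc2C(=O)Nc2ccncc2)c(OC)c1` gives < 0.02 h (a limit)

For compound 1 the reading of < 0.02 h is a limit of the assay and not a number. Within the data shown here, it has no firmer neighbours to be compared with, since every compound measured so far sits at that same limit (the limit of < 0.02 h in this assay, at which 3 of the 3 values shown sit).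

Compound 4 `COc1ccc(C[S+]([O-])c2ncccc2C(=O)Nc2ccncc2)c(OCCO)c1` turns the ethoxy of compound 1 into 2-hydroxyethoxy (hydroxy in place of hydrogen on a saturated chain carbon, two bonds along the chain from an oxygen on an aromatic ring). This places hydroxy in place of hydrogen on a saturated chain carbon, two bonds along the chain from an oxygen on an aromatic ring.

Among the measured compounds shown here, only one measured step bears on this change, and it is a step that the two limits leave unreadable from compound 1 to compound 2 with no size to carry over. No step beyond the scatter is therefore expected in this assay and no direction can be read, so another limit reading is likely. The expected change is a number no lower from compound 1 to compound 4 (the limit leaves the size open) (an estimate only).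

The estimate for compound 4 is 0.02 h (expected range 0.01 h to 0.05 h).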

Compound 4, half-life: < 0.02 h
Compound 4: only a limit was reported (the forecaster's own chance of this, stated with the estimate: 70%); the middle value lies on the limit itself.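

Among these compounds, compound 1 and compound 4 both read as limits of the assay and not as numbers, so no step between them can be read: the limit of < 0.02 h in this assay, at which 4 of the 4 values shown sit. The compounds shown leave open how long each one actually lasts, and whether 2-hydroxyethoxy in place of ethoxy changes the half-life at all.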